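Notes on the step from compound 2 to compound 3

This account rests on a few compounds, and the source may have more. Where it says the series, first, only, none or still open, it means among the compounds named here.

Values in a physicochemical assay for solubility, measured as thermodynamic solubility, at pH 7.4 (a higher number here means a more soluble compound, a lower number a less soluble compound), so far
- compound 1 (`CC(=O)NC1CCN(c2nc(NC(c3ccccc3)c3ccccc3)c3c(n2)C(=O)N(C(C)C)C3)C1`) gives < 1000 nM (a limit)
- compound 2 (`CC(C)N1Cc2c(NC(c3ccccc3)c3ccccc3)nc(N3CCN(S(C)(=O)=O)CC3)nc2C1=O`) gives < 1000 nM (a limit)

From the compounds shown here alone, compound 2 gives < 1000 nM as a limit and not as a number, so its exact standing is unknown. Both values shown sit at the same limit (the limit of < 1000 nM in this assay, at which 2 of the 2 values shown sit).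

The next compound to be measured is compound 3 (`CC(C)N1Cc2c(NC(c3ccccc3)c3ccccc3)nc(N3CCN(CC(=O)N(C)C)CC3)nc2C1=O`). It carries (dimethylcarbamoyl)methyl in place of methylsulfonyl on an amine nitrogen in a ring, and the rest of the structure stays the same ((dimethylcarbamoyl)methyl in place of methylsulfonyl on an amine nitrogen in a ring).

Among the measured compounds shown here, the only measured step is a step that the two limits leave unreadable from compound 1 to compound 2 and it offers no size to carry over. It also concerns a different place, an aromatic carbon. No direction can be drawn from these data, so no step beyond the scatter is expected in this assay on this evidence, and another limit would be no surprise.

The estimated step is a step that the limit leaves unreadable from compound 2 to compound 3 and it rests on a limit only. The expected value for compound 3 is 700 nM (estimated range 150 nM to 3000 nM).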

Compound 3, solubility: 3500 nM
Beside the measured number, compound 3's estimate is 5.0-fold (0.70 log units) below it; measured number above the stated range.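

In this assay, among the compounds shown here, compound 3 is the first compound to give a number and not a limit, which shows that the read-out can rise with a change on an amine nitrogen in a ring of the six-membered non-aromatic ring: (dimethylcarbamoyl)methyl in place of methylsulfonyl gives an at least 3.5-fold higher number from compound 2 to compound 3 (0.54 log units; beyond the scatter). Taken as a whole, 4-((dimethylcarbamoyl)methyl)piperazin-1-yl in place of 3-acetamidopyrrolidin-1-yl on an aromatic carbon gives an at least 3.5-fold higher number from compound 1 to compound 3 (0.54 log units; beyond the scatter). Both steps give only a lower bound on their size, and the step between the two limited compounds cannot be read, because neither of those compounds has a number: the limit of < 1000 nM in this assay, at which 2 of the 3 values shown sit.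

The compounds shown leave open whether the step depends on the dimethylamide, on the methylene link to the ring nitrogen, or simply on the departure of methylsulfonyl. From the compounds shown here alone, a primary amide, a carboxylic acid, a tertiary amine or a longer chain at the same ring nitrogen would help separate these readings, and how far the read-out can rise at this position also remains open.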